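The source may hold more compounds than are shown below. What is called first, only, known or untested is meant among the compounds shown, and "the series" means these compounds.

Compound 1 `COc1ccc(C(=O)c2ccc3c(c2)C=CC(C)(C)O3)c(NC(=O)CN)c1` was tested in a functional assay on A2780 cells (Homo sapiens) for antiproliferative activity, read by MTT assay, with a stated time of 48 h (on this read-out lower numbers stand for stronger inhibition and higher numbers for weaker inhibition), where compound 1 gives 590 nM. Compound 2 `CNCC(=O)Nc1cc(OC)ccc1C(=O)c1ccc2c(c1)C=CC(C)(C)O2` differs from it only by methyl in place of hydrogen on an amine nitrogen, and in this assay compound 2 gives 850 nM, so the step of a 1.4-fold higher number from compound 1 to compound 2 (0.16 log units; within the scatter). Compound 3 `C=C(c1ccc2c(c1)C=CC(C)(C)O2)c1ccc(OC)cc1NC(=O)CN` has a different core; how the two cores differ is not broken down here. In this assay compound 3 gives 140 nM, the lowest of the three numbers. Compound 4 `C=C(c1ccc2c(c1)C=CC(C)(C)O2)c1ccc(OC)cc1NC(=O)CNC` has not yet been measured; it differs from compound 3 by methyl in place of hydrogen on an amine nitrogen, the same change already seen between compound 1 and compound 2. A step of a 1.4-fold higher number from compound 3 to compound 4 (0.15 log units; within the scatter) is expected, because the earlier step of a 1.4-fold higher number from compound 1 to compound 2 (0.16 log units; within the scatter) stayed within the scatter. Compound 4 is therefore estimated at 200 nM, with a likely range from 100 nM to 420 nM.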

Compound 4, half-maximal inhibitory concentration: 320 nM
Compound 4: the middle estimate sits 1.6-fold (0.20 log units) below what was measured; the measured number falls inside the stated range.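

In this assay, methyl in place of hydrogen on the amine nitrogen gives a 2.3-fold higher number from compound 3 to compound 4 (0.36 log units; beyond the scatter), a modest loss of inhibition on this core. Set beside the earlier step, the result does not separate the two cores: the same change on two cores in this assay, a 1.4-fold higher number (0.16 log units; within the scatter) from compound 1 to compound 2 and a 2.3-fold higher number (0.36 log units; beyond the scatter) from compound 3 to compound 4, 1.6-fold (0.20 log units) apart, within the scatter of two such steps. The change therefore appears to carry over between these two cores, but two pairs of compounds say nothing about other cores and do not explain why the number rises.

The compounds shown leave open what a larger group on the same nitrogen would do on either core. Ethyl, a longer chain or a dimethylamino group in place of the methylamino group could each be compared with the methyl step.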